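The compounds below may be only part of what the source reports. "The series", "measured", "known", "first", "only" and "open" are said of these compounds alone.

Measured so far:
Compound 1 `CC(C)Cc1ccc(C(=O)/C=C/c2ccc(C(=O)O)cc2)cc1` — in an ADME assay on Vero cells (Chlorocebus sabaeus) for cytotoxicity, read by MTT assay, with a stated time of 72 h (on this read-out higher numbers stand for lower toxicity in this test and lower numbers for higher toxicity in this test), compound 1 gives < 10 ug/mL, which is a limit of this assay rather than a number.
Compound 2 `COC(=O)c1cc(-c2cccc(NC(=O)c3ccc(/C=C/C(=O)c4cccc([N+](=O)[O-])c4)cc3)c2)on1` — in this assay compound 2 gives > 40 ug/mL, again only a limit of this assay.

Compound 2 therefore stands at the less toxic end of what this assay can report, resting on the limit (the limit of > 40 ug/mL in this assay, at which 1 of the 2 values shown sits). Compound 1 rests on the opposite limit (the limit of < 10 ug/mL in this assay, at which 1 of the 2 values shown sits). No step between measured compounds is shown, so these two values show only that the compounds fall on different sides of the reported window.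

Compound 3 `COC(=O)c1cc(-c2cccc(NC(=O)c3ccc(/C=C/C(=O)c4cc(F)ccc4F)cc3)c2)on1` differs from compound 2 in a single place: 2,5-difluorophenyl in place of 3-nitrophenyl on a carbonyl carbon. For the measured compounds named here, with no measured step to guide the size, the change from compound 2 to compound 3 in this assay is expected to be none beyond the usual scatter, and the expected step that the limit leaves unreadable from compound 2 to compound 3 reflects that. Compound 3 is estimated at about 45 ug/mL, expected to fall between 20 ug/mL and 100 ug/mL, most likely reported once more as a limit only.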

Compound 3, half-maximal cytotoxic concentration: > 40 ug/mL
Compound 3 was reported as a limit; the forecaster's own chance of this, stated with the estimate: 70%; the middle value lies beyond the limit too.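

In this assay, no step can be read from compound 2 to compound 3, because both rest on the same limit: the limit of > 40 ug/mL in this assay, at which 2 of the 3 values shown sit.

From the compounds shown here alone, what stays open is how far beyond that limit each compound lies, and whether 2,5-difluorophenyl in place of 3-nitrophenyl changes the toxicity in this test at all.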